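Carbamoylmethyl Replacing (Azetidin-2-yl)carbonyl: Expected Stability

The compounds below may be only part of what the source reports. "The series", "measured", "known", "first", "only" and "open" are said of these compounds alone.

Compound 3 `COc1cc(C2CCN(C(=O)C3CCN3)CC2)ccc1Nc1ncc2ccc(-c3ccccc3OC)n2n1` was tested in an in vitro ADME assay on microsomes from liver (Rattus norvegicus, strain Sprague-Dawley) for metabolic stability, using NADPH, with a stated time of 10 min, tested at 0.5 uM (a higher number here means that the compound lasts longer, a lower number that the compound disappears faster), and compound 3 reaches > 0.666 h, which is a limit of the assay rather than a number. Compound 2 `COc1cc(C2CCN(C[C@@H](C)O)CC2)ccc1Nc1ncc2ccc(-c3ccccc3OC)n2n1` also gives a limit, > 0.666 h. Compound 1 `COc1cc(C2CCN(C[C@@H](C)O)CC2)ccc1Nc1ncc2ccc(-c3ccccc3N(C)S(C)(=O)=O)n2n1` gives 0.183 h, and the change an at least 3.6-fold higher number from compound 1 to compound 2 (0.56 log units; beyond the scatter) sits on an aromatic carbon, away from the place now altered. The step that the two limits leave unreadable from compound 2 to compound 3 sits on an amine nitrogen in a ring, the same place, but its size cannot be read because of the limit of > 0.666 h in this assay, at which 2 of the 3 values shown sit. Compound 4 `COc1cc(C2CCN(CC(N)=O)CC2)ccc1Nc1ncc2ccc(-c3ccccc3OC)n2n1` differs from compound 3 by carbamoylmethyl in place of (azetidin-2-yl)carbonyl on an amine nitrogen in a ring. With no readable step at this place, compound 4 is expected to stay near that limit, a step that the limit leaves unreadable from compound 3 to compound 4. The estimate for compound 4 is 0.8 h, between 0.35 h and 2 h.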

Compound 4, half-life: > 0.666 h
Compound 4 gave a limit, no number (the forecaster's own chance of this, stated with the estimate: 60%); the middle value is on the limit's open side.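

Compound 4 reaches > 0.666 h, a limit of the assay and not a number. Its steps from compound 2 and compound 3 cannot be read, since all three sit at one limit: the limit of > 0.666 h in this assay, at which 3 of the 4 values shown sit.

From the compounds shown here alone, whether compound 2, compound 3 and compound 4 truly differ in this assay, and by how much, stays open.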